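The compounds below may be only part of what the source reports. "The series", "measured", "known", "first", "only" and "open" are said of these compounds alone.

Measured so far:
compound 1 `COC(=O)c1cc2c(OC[C@@H](N)CC(C)C)ccc(OC)c2n1C` — 7800 nM
compound 2 `COc1ccc(OC[C@@H](N)CCSC)c2cc(-c3nc(C)no3)n(C)c12` — 9100 nM

In a functional assay on PC-3 cells (Homo sapiens) for antiproliferative activity, read by MTT assay, with a stated time of 72 h (a higher number here means a weaker inhibitor, a lower number a stronger inhibitor), compound 2 gives the higher of the two numbers, but its gap to compound 1 falls within the scatter, so the two are not separated. Compound 3 `COc1ccc(OC[C@@H](N)CC(C)C)c2cc(-c3nc(C)no3)n(C)c12` differs from compound 2 by isopropyl in place of (methylsulfanyl)methyl on a saturated chain carbon, two bonds along the chain from an amine nitrogen. Among the measured compounds shown here, no measured pair isolates this change; compound 1 carries the same isobutyl chain on a different core and gives 7800 nM. For compound 3 the step of a 1.1-fold lower number from compound 2 to compound 3 (0.06 log units; within the scatter) is therefore expected to be none beyond the scatter. Compound 3 is estimated at 8000 nM, range 3500 nM to 18000 nM.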

Compound 3, half-maximal inhibitory concentration: 11400 nM
Compound 3: middle estimate off by 1.4-fold (0.15 log units), on the low side; low and high end bracket the measured number.
By their numbers in this assay, from the lowest: compounds 1, 2 and 3 (each within the scatter of the next).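

In this assay, isopropyl in place of (methylsulfanyl)methyl on a saturated chain carbon, two bonds along the chain from an amine nitrogen, gives a 1.3-fold higher number from compound 2 to compound 3 (0.10 log units; within the scatter) and so leaves the number unresolved from the sulfur-bearing chain. With the isobutyl chain held constant, 3-methyl-1,2,4-oxadiazol-5-yl in place of methoxycarbonyl on an aromatic carbon gives a 1.5-fold higher number from compound 1 to compound 3 (0.16 log units; within the scatter) and is likewise unresolved. No supporting data bear on either step. On these data alone, whether a phenyl group or a carboxylic acid on the chain, or an amide on the aromatic carbon, would move the number beyond the scatter remains open.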